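Swapping fluoro for methyl on a weak cytotoxic ketone

The compounds below may be only part of what the source reports. "The series", "measured", "known", "first", "only" and "open" are said of these compounds alone.

Measured in a functional assay on HeLa cells (Homo sapiens) for cytotoxicity, read by sulforhodamine B assay, with a stated time of 48 h; a lower number here means a stronger inhibitor, a higher number a weaker inhibitor:
compound 1 `C=CCOc1ccc(F)cc1C(=O)c1cccnc1`: 93000 nM
compound 2 `O=C(c1cccnc1)c1cc(F)ccc1O`: 27000 nM
compound 3 `C=CCOc1ccc(Br)cc1C(=O)c1cccnc1`: 96000 nM

Compound 2 gives the lowest number of the three, clear of the other two beyond the scatter. Compound 4 `Cc1ccc(O)c(C(=O)c2cccnc2)c1` carries methyl in place of fluoro on an aromatic carbon, para to a hydroxy group: methyl in place of fluoro on an aromatic carbon. Among the measured compounds shown here, no measured step brings in methyl. The closest is bromo in place of fluoro on an aromatic carbon, a 1.0-fold higher number from compound 1 to compound 3 (0.01 log units; within the scatter), which stayed within the scatter. The modest step of a 3.4-fold lower number from compound 1 to compound 2 (0.54 log units; beyond the scatter) concerns hydrogen in place of allyl on an oxygen, a different place, and bears little on this change. In this assay no step beyond the scatter is therefore expected. The expected step is a 1.1-fold higher number from compound 2 to compound 4 (0.05 log units; within the scatter). Compound 4 is estimated at 30000 nM, within a range of 14000 nM to 65000 nM.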

Compound 4, half-maximal inhibitory concentration: 26000 nM
The estimate for compound 4 lay 1.2-fold (0.06 log units) above the measured number, within the range that was stated.
By their numbers in this assay, from the lowest: compounds 4 and 2 (each within the scatter of the next); then compounds 1 and 3 (each within the scatter of the next).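

In this assay, methyl in place of fluoro on an aromatic carbon, para to a hydroxy group, gives a 1.0-fold lower number from compound 2 to compound 4 (0.02 log units; within the scatter), so this swap leaves the number within the scatter. The earlier compounds had shown only one halogen exchanged for another at this position, and on allyl-bearing compounds; this result extends that to a non-halogen group on a compound with a free hydroxy group. No evidence at hand accounts for this result. The compounds shown leave open whether an amine or a carboxylic acid on this carbon would also keep the number there, and whether methyl would behave the same way with allyl on the oxygen.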